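Swapping 3-methoxyphenyl for 4-hydroxyphenyl on an amide nitrogen

This account rests on a few compounds, and the source may have more. Where it says the series, first, only, none or still open, it means among the compounds named here.

Of the compounds shown here, three with a shared core have been tested in a functional assay on T47D cells (Homo sapiens) for inhibition, read by CCK-8 assay, with a stated time of 72 h, tested at 10 uM (on this read-out higher numbers stand for more inhibition of growth at the one concentration tested and lower numbers for less inhibition of growth), so far. Compound 1 (`CN(C)C(=O)c1cc2cnc(Nc3ccc(NC(=O)C4(C(=O)Nc5cccc(O)c5)CC4)cc3)nc2n1C1CCCC1`) gives 83.7% and compound 2 (`COc1ccc(NC(=O)C2(C(=O)Nc3ccc(Nc4ncc5cc(C(=O)N(C)C)n(C6CCCC6)c5n4)cc3)CC2)cc1`) gives 96.1% there. Compound 3 (`COc1cccc(NC(=O)C2(C(=O)Nc3ccc(Nc4ncc5cc(C(=O)N(C)C)n(C6CCCC6)c5n4)cc3)CC2)c1`) gives 93.5% and so lies within the scatter of both others.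

Compound 4 (`CN(C)C(=O)c1cc2cnc(Nc3ccc(NC(=O)C4(C(=O)Nc5ccc(O)cc5)CC4)cc3)nc2n1C1CCCC1`) is still unmeasured. It has 4-hydroxyphenyl in place of the 3-methoxyphenyl of compound 3 on an amide-type nitrogen (4-hydroxyphenyl in place of 3-methoxyphenyl on an amide-type nitrogen).

Within the data shown here, three measured steps bear on this. Exchanging 4-methoxyphenyl for 3-methoxyphenyl gives a number 2.6 percentage points lower from compound 2 to compound 3 (within the scatter) and so shows little on its own. Methyl in place of hydrogen on an oxygen on an aromatic ring gives a number 9.8 percentage points higher from compound 1 to compound 3 (within the scatter) as a possible hint only. Among the measured compounds shown here, the one step beyond the scatter, 4-methoxyphenyl in place of 3-hydroxyphenyl, gives a number 12.4 percentage points higher from compound 1 to compound 2 (beyond the scatter) and is modest. For the measured compounds named here, compound 1 is the only measured compound with a hydroxyphenyl group, so the evidence is thin.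

A small fall is expected, and the estimated step is a number 6.5 percentage points lower from compound 3 to compound 4 (within the scatter) in this assay without clearly leaving the scatter. For compound 4 the estimated value is 87% within an expected range from 76% to 96% on this read-out.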

Compound 4, percent growth inhibition at one concentration: 95.8%
Estimate against measurement, compound 4: 8.8 percentage points below, within the range that was stated.
By their numbers in this assay, from the lowest: compounds 1, 3, 4 and 2 (each within the scatter of the next, the first and the last beyond it).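

In this assay, 4-hydroxyphenyl in place of 3-hydroxyphenyl on the amide-type nitrogen gives a number 12.1 percentage points higher from compound 1 to compound 4 (beyond the scatter), so a hydroxyphenyl group at this position does not by itself rule out a high number. Replacing 3-methoxyphenyl with 4-hydroxyphenyl gives a number 2.3 percentage points higher from compound 3 to compound 4 (within the scatter), and hydrogen in place of methyl on the oxygen gives a number 0.3 percentage points lower from compound 2 to compound 4 (within the scatter), so neither change can be told from the scatter. The earlier hint that methyl on this oxygen helps is not confirmed, and the two readings of that change cannot be told apart either: the same change on two cores in this assay, a number 9.8 percentage points higher (within the scatter) from compound 1 to compound 3 and a number 0.3 percentage points higher (within the scatter) from compound 4 to compound 2, 9.5 percentage points apart, within the scatter of two such steps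

As far as these compounds go, how an amine or a carboxylic acid on this phenyl ring would compare remains open. From the compounds shown here alone, with one concentration tested, any ranking of compound 2, compound 3 and compound 4 also remains open.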